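Bromine for fluorophenyl: will the cells still be spared?

The compounds below may be only part of what the source reports. "The series", "measured", "known", "first", "only" and "open" are said of these compounds alone.

Measured compounds, all in an ADME assay on BJ cells (Homo sapiens) for cytotoxicity, read by CellTiter-Glo and resazurin assay, with a stated time of 72 h; on this read-out lower numbers stand for an effect already at smaller amounts and higher numbers for an effect only at larger amounts of compound:
compound 1, `CCOC(=O)CCCCCOc1cccc(CN(C(=O)c2ccc(-c3cccc(C(C)=O)c3)cc2)C(C)C)c1`: > 26000 nM
compound 2, `CCOC(=O)CCCCCOc1cccc(CN(C(=O)c2ccc(-c3cccc(-c4nnc(C)o4)c3)cc2)C(C)C)c1`: > 26000 nM
compound 3, `CCOC(=O)CCCCCOc1cccc(CN(C(=O)c2ccc(-c3cccc(F)c3)cc2)C(C)C)c1`: > 26000 nM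

Every one of these three values is a limit of the assay, not a measured number. Compound 3 therefore stands nowhere in particular: its value of > 26000 nM only says that no effect on the cells was seen up to that limit. The same holds for the other two, as shown by the limit of > 26000 nM in this assay, at which 3 of the 3 values shown sit. Because of this the three steps that connect the measured compounds cannot be read: a step that the two limits leave unreadable from compound 1 to compound 2, a step that the two limits leave unreadable from compound 1 to compound 3 and a step that the two limits leave unreadable from compound 2 to compound 3 are all unreadable in size.

Compound 4, `CCOC(=O)CCCCCOc1cccc(CN(C(=O)c2ccc(Br)cc2)C(C)C)c1`, differs from compound 3 in one place: bromo in place of 3-fluorophenyl on an aromatic carbon. Among the compounds with values here, none of the measured steps touches this place, and none gives a size. What the measured compounds do show is that three different groups on this part of the molecule all left the cells untouched. On that basis compound 4 is expected to stay at the limit as well, with a step that the limit leaves unreadable from compound 3 to compound 4 from compound 3. The estimate for compound 4 in this assay is 30000 nM, within 12000 nM to 80000 nM.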

Compound 4, half-maximal effective concentration: > 26000 nM
Compound 4 ended at the assay's limit (the forecaster's own chance of this, stated with the estimate: 80%); the middle value lies beyond the limit too.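

No size can be read for the steps joining compound 4 to compound 1, compound 2 and compound 3, because all four compounds sit at the same limit, which is not a measured number: the limit of > 26000 nM in this assay, at which 4 of the 4 values shown sit.

In this assay, as far as these compounds go, the concentration at which any of these four compounds would affect the cells stays open, as does whether they differ from one another.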